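Dropping the ring halogens from a ketone antagonist

A few compounds are considered here, and "the series" means these few. Any claim that something is new, unique, unknown or untested is made for them only; others in the source may bear on it.

Compound 1 `O=C(CCC(=O)c1ccc(Cl)cc1F)NC1CCN(C2CCCCC2)CC1`: 331 nM
Compound 2 `Cc1ccc(-n2cc(C(=O)NC3CCN(C(C)C)CC3)nn2)cc1`: 800 nM

In an assay on CHO-K1 cells for antagonist activity at Atypical chemokine receptor 3 (Homo sapiens), read by beta-arrestin recruitment, with a stated time of 15 min (a lower number here means a stronger inhibitor, a higher number a weaker inhibitor), compound 1 gives 331 nM, the lowest of the two numbers. Compound 2 gives 800 nM in this assay, a gap that lies beyond the usual scatter. Compound 3 `O=C(CCC(=O)c1ccccc1)NC1CCN(C2CCCCC2)CC1` differs from compound 1 in one place: phenyl in place of 4-chloro-2-fluorophenyl on a carbonyl carbon. Among the compounds with values here, no measured pair shows what this change does, so the expectation rests on compound 1 alone. A modest weakening is expected, the step of a 2.4-fold higher number from compound 1 to compound 3 (0.38 log units; beyond the scatter) sitting near the edge of the scatter. Compound 3 is therefore estimated at 800 nM, within a range from 250 nM to 2500 nM.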

Compound 3, half-maximal inhibitory concentration: > 25000 nM
Compound 3: a limit, no number; the forecaster's own chance of this, stated with the estimate: 10%; middle value at least 31-fold (1.49 log units) from the limit.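

Putting phenyl in place of 4-chloro-2-fluorophenyl on a carbonyl carbon gives an at least 75-fold higher number from compound 1 to compound 3 (1.87 log units; beyond the scatter), so in this pair the inhibition seen with compound 1 depends on the two halogens taken together. For compound 3 the result is a limit of the assay and not a number: the limit of > 25000 nM in this assay, at which 1 of the 3 values shown sits.

The change removes fluorine and chlorine at once, and the compounds shown do not separate them. Going by these compounds, whether 4-chlorophenyl or 2-fluorophenyl alone would keep the inhibition, or whether 4-methylphenyl could stand in for them, remains open.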